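A few compounds are considered here, and "the series" means these few. Any claim that something is new, unique, unknown or untested is made for them only; others in the source may bear on it.

Working notes on the series. Three compounds have so far been run in an ADME assay on PC-3 cells (Homo sapiens) for cytotoxicity, read by WST assay, tested at 100 uM; on this read-out lower numbers stand for less inhibition and higher numbers for more inhibition at the one concentration tested (going by the name of the read-out). Compound 1 `O=C(Nc1cccc(Oc2ccccn2)c1)C1CCCN(C(=O)c2cc(C(F)(F)F)cc(C(F)(F)F)c2)C1` gives 0% in this assay. Compound 2 `CSc1cccc(C(=O)N2CCCC(C(=O)Nc3ccc(Cl)cc3)C2)c1` gives 0% in this assay, level with compound 1 at the digits reported. Compound 3 `O=C(Nc1ccc(Cl)cc1)C1CCCN(C(=O)c2ccc(-c3ccco3)cc2)C1` gives 6% in this assay, a number that sits within the usual scatter of the values for compound 1 and compound 2. Going by the values given here, no pair of measured compounds differs in a single place, so nothing in the set yet shows a single change moving the read-out one way or the other.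

Compound 4 `O=C(Nc1cccc(Oc2ccccc2)c1)C1CCCN(C(=O)c2cc(C(F)(F)F)cc(C(F)(F)F)c2)C1` has not been measured. It differs from compound 1 in one place: phenyl in place of pyridin-2-yl on an oxygen on an aromatic ring. The change sits on an oxygen on an aromatic ring whose other neighbours are aromatic carbon, and taken one bond further out it reads as (pyridin-2-yl)oxy to phenoxy. The read-out for compound 4 is expected to remain low, because compound 1 gives 0% and the two other measured compounds stay within the scatter of that number. The expected step of a number 3 percentage points higher from compound 1 to compound 4 (within the scatter) is none beyond the scatter. Compound 4 is estimated at 3%, with a range from 0% to 15%.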

Compound 4, a percentage reported as inhibition, at one concentration (the size of the read-out at that concentration, not a potency): 1%
Estimate against measurement, compound 4: 2 percentage points above, within the range that was stated.
By their numbers in this assay, from the lowest: compounds 1, 2, 4 and 3 (each within the scatter of the next).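

Going by these compounds alone, the replacement of pyridin-2-yl by phenyl on an oxygen on an aromatic ring is the only single change in the set so far, and in this assay it reads as a number 1 percentage points higher from compound 1 to compound 4 (within the scatter). Within the data shown here, at this place, then, exchanging the ring with one hetero atom and one hydrogen-bond acceptor for a ring of carbon only, with the same count of heavy atoms, does not shift the read-out beyond the scatter at the one concentration tested, something the earlier compounds, which differ from each other in more than one place, could not show. Nothing available bears on the reason for this result.

Still open, going by these compounds, is whether a group of another kind at this place, such as an amine or a carboxylic acid in place of the phenyl, would take this assay beyond the scatter, since both groups seen here are six-membered aromatic rings. On these data alone, the two trifluoromethyl groups on the other side of the core of compound 1 also remain untested by any single change, so a replacement there, for example by a methoxy group, could not yet be judged from these compounds.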